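The source may report more compounds than this note shows. Statements on the series, on what has been measured and on what is new or still open speak of the compounds shown alone.

Measured so far in an assay on isolated protein for displacement of a labelled ligand from secreted frizzled-related protein 1 (Homo sapiens), read by fluorescence polarization, with a stated time of 30 min; a lower number here means a stronger inhibitor, a higher number a weaker inhibitor:
compound 1 `O=C(c1ccccc1)N1CCC(NS(=O)(=O)c2cc(S(=O)(=O)c3ccccc3)ccc2C(F)(F)F)CC1` gives 70 nM;
compound 2 `O=C(c1ccc(Cl)cc1)N1CCC(NS(=O)(=O)c2cc(S(=O)(=O)c3ccccc3)ccc2C(F)(F)F)CC1` gives 300 nM;
compound 3 `CN(C)c1ccc(C(=O)N2CCC(NS(=O)(=O)c3cc(S(=O)(=O)c4ccccc4)ccc3C(F)(F)F)CC2)cn1` gives 40 nM.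

Among these three numbers compound 1 stands second highest. Its nearest neighbour is compound 3, reached by a 1.8-fold lower number from compound 1 to compound 3 (0.24 log units; within the scatter), a gap within the scatter; its furthest is compound 2, reached by a 4.3-fold higher number from compound 1 to compound 2 (0.63 log units; beyond the scatter). The remaining step, a 7.5-fold lower number from compound 2 to compound 3 (0.88 log units; beyond the scatter), also lies at the benzoyl end of the molecule.

Compound 4 `O=S(=O)(NC1CCN(S(=O)(=O)c2ccccc2)CC1)c1cc(S(=O)(=O)c2ccccc2)ccc1C(F)(F)F` departs from compound 1 elsewhere: phenylsulfonyl in place of benzoyl on an amine nitrogen in a ring All three measured steps change only the aromatic ring on the carbonyl carbon, so none of them speaks directly to swapping the amide linkage itself for a sulfonyl one. The measured steps show that changes at this end of the shared core move the number only modestly, and the same is expected here: compound 4 is expected to sit close to compound 1, with a 1.4-fold higher number from compound 1 to compound 4 (0.15 log units; within the scatter) not clearly beyond the scatter. The estimate for compound 4 in this assay is 100 nM, within a range from 30 nM to 350 nM.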

Compound 4, half-maximal inhibitory concentration: 130 nM
Estimate against measurement, compound 4: 1.3-fold (0.11 log units) below; the range from low to high includes it.
By their numbers in this assay, from the lowest: compounds 3, 1 and 4 (each within the scatter of the next, the first and the last beyond it); then compound 2.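

Among the compounds shown here, compound 4 is the first change to the link itself rather than to the aromatic ring on the carbonyl carbon, and in this assay phenylsulfonyl in place of benzoyl gives a 1.9-fold higher number from compound 1 to compound 4 (0.27 log units; within the scatter) and so leaves compound 4 not distinguishable from compound 1, which shows that this position does not depend on the carbonyl for a number of this size. The steps of a 3.3-fold higher number from compound 3 to compound 4 (0.51 log units; beyond the scatter) and a 2.3-fold lower number from compound 2 to compound 4 (0.36 log units; beyond the scatter) both lie beyond the scatter, but each changes the link and the ring substituents together, so neither separates the two. No measurement given here accounts for this result.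

As far as these compounds go, it remains open whether 4-chlorophenylsulfonyl or (6-(dimethylamino)pyridin-3-yl)sulfonyl on this nitrogen would follow the order seen in the amides. A benzyl group, with neither carbonyl nor sulfonyl, also remains untested among the compounds shown.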